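The source may hold more compounds than are shown below. What is called first, only, known or untested is meant among the compounds shown, and "the series" means these compounds.

Among the measured compounds shown here, compound 1 `Cc1cc(Nc2nc(NCc3ccc(F)cc3F)nc3ccccc23)n[nH]1` is one of two compounds measured in an assay for inhibition of high affinity nerve growth factor receptor (Homo sapiens), read by HTRF, with a stated time of 30 min, in the presence of a further agent that is not named here; on this read-out lower numbers stand for stronger inhibition and higher numbers for weaker inhibition. In this assay compound 1 gives 200 nM, the lowest of the two numbers. Compound 2 `Cc1cc(Nc2nc(NCc3cc(F)c(F)c(F)c3)nc3ccccc23)n[nH]1` differs from it only in the pendant fluorinated ring, and in this assay compound 2 gives 870 nM; the step of a 4.4-fold higher number from compound 1 to compound 2 (0.64 log units; beyond the scatter) lies beyond the scatter. Compound 3 `Cc1cc(Nc2nc(NCc3ccc(F)cc3F)nc3ccc(C(F)(F)F)cc23)n[nH]1` keeps the 2,4-difluorophenyl of compound 1 and differs instead at the shared core: trifluoromethyl in place of hydrogen on an aromatic carbon, on an aromatic carbon of a six-membered aromatic ring of carbon only, part of a fused system of two rings. For the measured compounds named here, the single measured step changes the pendant ring and not the core, so no measured step bears on this change, and the core substitution has no precedent here. The step of no change at the digits printed from compound 1 to compound 3 (within the scatter) is therefore expected to stay within the scatter. The estimate for compound 3 in this assay is 200 nM, with a range from 70 nM to 600 nM.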

Compound 3, half-maximal inhibitory concentration: 370 nM
Compound 3: the middle estimate sits 1.9-fold (0.27 log units) below what was measured, and the stated range covers the measured number.
By their numbers in this assay, from the lowest: compounds 1 and 3 (each within the scatter of the next); then compound 2.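

In this assay, among the compounds shown here, the swap of trifluoromethyl for hydrogen gives a 1.9-fold higher number from compound 1 to compound 3 (0.27 log units; within the scatter) and this is the first measured step at the shared core rather than at the pendant fluorinated ring. It shows that this aromatic carbon, meta to a fused ring and para to a fused ring, can carry a group of 4 heavy atoms while the numbers of the two compounds remain within the scatter of each other. Nothing given here accounts for this result.

On these data alone, whether an amine, a carboxylic acid or a methoxy group on this same carbon would also remain within the scatter of compound 1 stays open. Also open, as far as these compounds go, is whether trifluoromethyl here would give a similar step alongside the 3,4,5-trifluorophenyl of compound 2.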